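This account rests on a few compounds, and the source may have more. Where it says the series, first, only, none or still open, it means among the compounds named here.

Working notes on the series. Compound 1 `O=C(CN1CCN(c2nnc(Cc3ccncc3)c3ccccc23)CC1)Nc1ccc(F)c(Cl)c1` gives 4 nM in a functional assay on MDA-MB-231 cells (Homo sapiens) for cytotoxicity, read by MTT assay, with a stated time of 72 h (a higher number here means a weaker inhibitor, a lower number a stronger inhibitor), and compound 2 `O=C(CN1CCN(c2nnc(Cc3ccncc3)c3ccccc23)CC1)Nc1ccc(F)c(C(F)(F)F)c1` gives 1.9 nM. The step of a 2.1-fold lower number from compound 1 to compound 2 (0.32 log units; beyond the scatter) shows compound 2 standing lowest of the two numbers, with compound 1 nearest. Compound 3 `O=C(CN1CCN(c2nnc(Cc3ccncc3)c3ccccc23)CC1)Nc1c(F)cccc1F` differs from compound 2 by 2,6-difluorophenyl in place of 4-fluoro-3-(trifluoromethyl)phenyl on an amide-type nitrogen. Going by the values given here, only the step from compound 1 to compound 2 bears on this change, and it was modest, so a step of comparable or somewhat larger size is expected, most likely toward a higher number, since no measured compound shows this substitution pattern. Compound 3 is estimated at 8 nM, range 2 nM to 40 nM, a step of a 4.2-fold higher number from compound 2 to compound 3 (0.62 log units; beyond the scatter).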

Compound 3, half-maximal inhibitory concentration: 1900 nM
Beside the measured number, compound 3's estimate is 240-fold (2.38 log units) below it, outside the stated range (above it).
By their numbers in this assay, from the lowest: compound 2; then compound 1; then compound 3.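

On the amide-type nitrogen, the choice of aryl group matters greatly in this assay: the change gives a 1000-fold higher number from compound 2 to compound 3 (3.00 log units; beyond the scatter), and a 480-fold higher number from compound 1 to compound 3 (2.68 log units; beyond the scatter). Exchanging chloro for trifluoromethyl moved the number only modestly, whereas replacing the whole substituted phenyl with 2,6-difluorophenyl moves it far more. No measured evidence bears on the reason for this step. The compounds shown leave open whether the large step follows from the presence of 2,6-difluorophenyl or the absence of the chloro or trifluoromethyl group. A 4-fluorophenyl or 2-fluorophenyl group on this nitrogen would help separate these readings.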